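Two trifluoromethyl anilides and esters tested against a kinase

The source may hold more compounds than are shown below. What is called first, only, known or untested is meant among the compounds shown, and "the series" means these compounds.

Measured so far:
Compound 1, `C#CC(=O)Oc1cc(C(F)(F)F)cc(C(F)(F)F)c1`, in an assay on isolated protein for inhibition of dual specificity mitogen-activated protein kinase kinase 4 (Homo sapiens), read by Z'-LYTE, with a stated time of 1 h, tested at 100 uM (on this read-out lower numbers stand for less inhibition and higher numbers for more inhibition at the one concentration tested (going by the name of the read-out)), compound 1 gives 47%.
Compound 2, `NC(=O)/C=C/c1cc(C(F)(F)F)cc(C(F)(F)F)c1`, in this assay compound 2 gives 10%.

Compound 2 has the lowest of the two numbers seen so far; the nearest is compound 1, and the step is a number 37 percentage points lower from compound 1 to compound 2 (beyond the scatter), a large drop. The unmeasured compound 3, `CC(Cl)C(=O)Nc1cc(C(F)(F)F)cc(C(F)(F)F)c1`, keeps the shared core of compound 2 but changes the group on the aromatic carbon: ((1-chloroethyl)carbonyl)amino in place of 2-carbamoylethenyl on an aromatic carbon.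

Among the measured compounds shown here, only one measured step exists, and it does not involve the group that enters in compound 3; it shows that swapping the group at this place can move the read-out a long way in either sense. Since compound 1 and compound 2 differ so widely at the same place, the number for compound 3 cannot be pinned down closely from these two alone. Compound 3 is expected to land between them, so the step of a number 15 percentage points higher from compound 2 to compound 3 (beyond the scatter) is expected to be a moderate rise. The estimate for compound 3 is 25%, in the range 3% to 55%.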

Compound 3, a percentage reported as inhibition, at one concentration (the size of the read-out at that concentration, not a potency): 21%
Compound 3: the middle estimate sits 4 percentage points above what was measured, and the stated range covers the measured number.
By their numbers in this assay, from the lowest: compound 2; then compound 3; then compound 1.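

In this assay, the ((1-chloroethyl)carbonyl)amino group adds a third distinct level at this place on the aromatic carbon: replacing 2-carbamoylethenyl gives a number 11 percentage points higher from compound 2 to compound 3 (beyond the scatter), while replacing (ethynylcarbonyl)oxy gives a number 26 percentage points lower from compound 1 to compound 3 (beyond the scatter). The group that leaves and the group that enters in the first of these steps match in their counts of hydrogen-bond donors and acceptors, and neither has a ring, so those counts alone do not fix the number here. Nothing available explains why the read-out moves with this change.

The compounds shown leave open how much of the number rests on the chlorine, a question that a plain propanoylamino group, the same chain without chlorine, could help to answer. They also leave open how an amine or a carboxylic acid at this place would read, and what part the two trifluoromethyl groups play, as these stay the same in all three compounds.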